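A few compounds are considered here, and "the series" means these few. Any claim that something is new, unique, unknown or untested is made for them only; others in the source may bear on it.

For the measured compounds named here, compound 2 `C=CCN(Cc1cccs1)C(=O)COc1ccc(C)cc1` stands alongside compound 1 `CCCN(Cc1cccs1)C(=O)COc1ccc(C)cc1` as one of only two compounds measured, and in an assay on HEK293 cells for agonist activity at transient receptor potential cation channel subfamily M member 8 (Homo sapiens), read by fluorescence and calcium flux, with a stated time of 15 min (on this read-out higher numbers stand for an effect only at larger amounts of compound and lower numbers for an effect already at smaller amounts), compound 2 gives 20 nM. In this assay compound 1 gives 40 nM. The gap between them is a 2.0-fold lower number from compound 1 to compound 2 (0.30 log units; within the scatter). Compound 3 `Cc1ccc(OCC(=O)N(Cc2cccs2)C2CC2)cc1` differs from compound 2 by cyclopropyl in place of allyl on an amide-type nitrogen. Going by the values given here, the single measured step, vinyl in place of ethyl on the same nitrogen's chain, stayed within the scatter, so a change of similar size, with no clear direction, is expected in this assay here. Compound 3 is therefore estimated at 30 nM, expected between 10 nM and 90 nM. That expected step is a 1.5-fold higher number from compound 2 to compound 3 (0.18 log units; within the scatter).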

Compound 3, half-maximal effective concentration: 8 nM
Beside the measured number, compound 3's estimate is 3.8-fold (0.57 log units) above it; the measured number lies below the stated range.
By their numbers in this assay, from the lowest: compound 3; then compounds 2 and 1 (each within the scatter of the next).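

Going from an open three-carbon group to cyclopropyl on the amide-type nitrogen gives the first changes beyond the scatter in this assay: a 2.5-fold lower number from compound 2 to compound 3 (0.40 log units; beyond the scatter), and a 5.0-fold lower number from compound 1 to compound 3 (0.70 log units; beyond the scatter). This position therefore responds to which three-carbon group it carries, even though the number of heavy atoms stays the same. Nothing available here gives a reason for this difference. Still open, going by these compounds, is how cyclobutyl, a larger ring, or butyl, a longer chain, would read at this nitrogen.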